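Removing one methoxy group from compound 3

The source may report more compounds than this note shows. Statements on the series, on what has been measured and on what is new or still open speak of the compounds shown alone.

Three compounds have numbers in a functional assay on ACHN cells (Homo sapiens) for inhibition, read by sulforhodamine B assay, with a stated time of 48 h; a higher number here means a weaker inhibitor of growth, a lower number a stronger inhibitor of growth. Compound 1 `N#C/C(=C\c1c(-c2ccccc2)[nH]c2ccccc12)C(=O)c1ccccc1` gives 7200 nM and compound 2 `O=C(/C(=C\c1c(-c2ccccc2)[nH]c2ccccc12)S(=O)(=O)c1ccccc1)c1ccccc1` gives 6700 nM; those two values lie within the scatter of each other. Compound 3 `COc1ccc(-c2[nH]c3ccc(OC)cc3c2/C=C(\C#N)S(=O)(=O)c2ccccc2)cc1` gives 1800 nM, the lowest of the three, and its gaps to compound 2 and to compound 1 are both beyond the scatter, so compound 3 is the strongest growth inhibitor measured so far. Among the measured compounds shown here, no pair of measured compounds differs in a single place, so no measured step isolates the methoxy groups; compound 1 and compound 2 lack both of them but also differ from compound 3 elsewhere.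

Compound 4 `COc1ccc(-c2[nH]c3ccccc3c2/C=C(\C#N)S(=O)(=O)c2ccccc2)cc1` keeps the shared core of compound 3 and differs in one place: hydrogen in place of methoxy on an aromatic carbon. For the measured compounds named here, with no measured step to lean on, the expectation is a modest move toward a higher number, of the order of the scatter or slightly beyond it, a 1.6-fold higher number from compound 3 to compound 4 (0.19 log units; within the scatter). Compound 4 is therefore expected in this assay at about 2800 nM, within a range from 1200 nM to 6500 nM.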

Compound 4, concentration for 50% growth inhibition: 1900 nM
Estimate against measurement, compound 4: 1.5-fold (0.17 log units) above; measured number inside the range.
By their numbers in this assay, from the lowest: compounds 3 and 4 (each within the scatter of the next); then compounds 2 and 1 (each within the scatter of the next).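

Hydrogen in place of methoxy at this aromatic carbon, meta to a fused ring and para to a fused ring, gives a 1.1-fold higher number from compound 3 to compound 4 (0.02 log units; within the scatter) in this assay. Among the compounds shown here, this is the first single-place step, and it shows that this methoxy group can be removed with no change beyond the scatter in this read-out. The data available give no reason for this result.

As far as these compounds go, only hydrogen and methoxy have been compared at this carbon, so it remains open whether an amine, a carboxylic acid or a longer alkoxy chain would also leave the number within the scatter. For the compounds shown here, the methoxy group that remains in compound 4 has no single-place step of its own, so its contribution also remains open.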